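Trimming the Side Chain of Compound 1

A few compounds are considered here, and "the series" means these few. Any claim that something is new, unique, unknown or untested is made for them only; others in the source may bear on it.

Two compounds have been measured in a functional assay on the whole organism (strain Swiss) with Mus musculus as the target, in the maximal electroshock model, with a stated time of 1 h, at a dose of 100 mg/kg by the intraperitoneal route; on this read-out higher numbers stand for a stronger effect at the one dose given and lower numbers for a weaker effect:
compound 1, `COCC(C(=O)N1CCN(c2cccc(C(F)(F)F)c2)CC1)N1C(=O)CCC1=O`, gives 50%
compound 2, `CCC(C(=O)N1CCN(c2cccc(C)c2)CC1)N1C(=O)CCC1=O`, gives 0%

On these two numbers compound 1 stands highest, and compound 2 lies far below it, by more than the usual scatter of repeated tests of this kind. The two differ in more than one place, so the gap cannot be tied to any single change; it only shows that compound 1 has a clear effect at the dose given while compound 2 shows none.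

Compound 3, `CC(C(=O)N1CCN(c2cccc(C(F)(F)F)c2)CC1)N1C(=O)CCC1=O`, has not yet been measured. It differs from compound 1 in one place only: hydrogen in place of methoxy on a saturated chain carbon, two bonds along the chain from an amide-type nitrogen in a ring and a carbonyl carbon. Seen one bond further out, the change reads methoxymethyl to methyl.

Among the compounds with values here, no measured pair shows what this change alone does in this assay, so its direction is open. Since compound 1 gives 50% while compound 2, carrying a plain chain, gives 0%, a moderate decrease is expected, with wide uncertainty. Compound 3 is expected to give 30%, within a range from 0% to 70%. That corresponds to an expected step of a number 20 percentage points lower from compound 1 to compound 3 (beyond the scatter) in this assay.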

Compound 3, a percentage reported as activity, at one dose (the size of the read-out at that dose, not a potency): 50%
For compound 3 the middle estimate is 20 percentage points below the measured one; low and high end bracket the measured number.
By their numbers in this assay, from the lowest: compound 2; then compounds 1 and 3 (each within the scatter of the next).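

In this assay, putting hydrogen in place of methoxy on the saturated chain carbon gives no change at the digits printed from compound 1 to compound 3 (within the scatter), so at this place the methoxymethyl group can be cut back to methyl with no visible loss at the one dose given. Within the data shown here, this is the first comparison here that changes a single place, and it shows that the methoxy is not needed to keep this read-out, whereas the gap between the two earlier compounds could not be tied to any one change. The read-out is the size of an effect at one dose, not a potency, and nothing given here explains why the methoxy can go.

Still open, from the compounds shown here alone, is how much else this chain carbon can carry: a longer chain such as butyl, an amine such as aminomethyl, or a carboxylic acid could keep the effect or lose it. The part played by the trifluoromethyl group on the other side of the molecule also stays open, since no pair shown changes that group alone.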